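The compounds below may be only part of what the source reports. "The series", "measured", "known", "first", "only" and "open" are said of these compounds alone.

Working notes on the series.

Of the compounds shown here, three have been measured in a functional assay on COLO 205 cells (Homo sapiens) for inhibition, read by sulforhodamine B assay, with a stated time of 48 h; on this read-out lower numbers stand for higher toxicity in this test and higher numbers for lower toxicity in this test. Compound 1 `COc1cc(C)cc(-c2c(-c3ccnc(-c4ccc(C(C)=O)cc4)c3)cnn2CC#N)c1` gives 7020 nM in this assay. Compound 2 `Cc1cc(O)cc(-c2nn(CC#N)cc2-c2ccnc(-c3ccc(Oc4ccccc4)cc3)c2)c1` gives 5900 nM in this assay. Compound 3 `COc1cc(C)cc(-c2nn(CC#N)cc2-c2ccnc(-c3ccc(N(C)C)cc3)c2)c1` gives 3910 nM in this assay, the lowest of the three numbers, though its gaps to compound 2 and to compound 1 are both within the usual scatter of repeated measurements, so the three cannot be separated on these data.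

Compound 4 `Cc1cc(O)cc(-c2nn(CC#N)cc2-c2ccnc(-c3ccc(N(C)C)cc3)c2)c1` is not yet measured. Compound 4 differs from compound 3 in one place: hydrogen in place of methyl on an oxygen on an aromatic ring, that is, methoxy to hydroxy on the 3-methoxy-5-methylphenyl ring, giving 3-hydroxy-5-methylphenyl. Within the data shown here, no pair of measured compounds in this assay differs by only this change; compound 2 carries the hydroxy and compound 1 the methoxy, but they differ elsewhere as well, and their numbers lie within the scatter of each other. No step beyond the scatter is therefore expected in this assay from compound 3 to compound 4, in either direction. For compound 4 the expected value in this assay is 4500 nM, with a range of 2000 nM to 10000 nM; the step this estimate implies is a 1.2-fold higher number from compound 3 to compound 4 (0.06 log units; within the scatter).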

Compound 4, concentration lethal to 50% of the cells: 87800 nM
Estimate against measurement, compound 4: 20-fold (1.29 log units) below; the measured number lies above the stated range.
By their numbers in this assay, from the lowest: compounds 3, 2 and 1 (each within the scatter of the next); then compound 4.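

In this assay, methoxy to hydroxy on the 3-methoxy-5-methylphenyl ring gives a 22-fold higher number from compound 3 to compound 4 (1.35 log units; beyond the scatter), towards lower toxicity in this test, so with dimethylamino in the compound this place is not indifferent to the change. With the hydroxy held, dimethylamino in place of phenoxy gives a 15-fold higher number from compound 2 to compound 4 (1.17 log units; beyond the scatter), so the number also responds to the group at that second place, and the two large steps both end at compound 4. No measurement at hand accounts for either step.

On these data alone, whether methoxy to hydroxy gives a step of this size with phenoxy in place of dimethylamino stays open. Also open, as far as these compounds go, is what an ethoxy group or an amine would give in place of the hydroxy.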